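Swapping the acid arm on a shared core

This account rests on a few compounds, and the source may have more. Where it says the series, first, only, none or still open, it means among the compounds named here.

Measured so far:
compound 1, `O=C(O)c1ccc(NCc2cccc(Oc3ccccc3)c2)cc1`, reaches 86% in a functional assay on CHO cells for agonist activity at Free fatty acid receptor 1 (Homo sapiens), read by a luciferase reporter; a lower number here means a smaller maximal response, a higher number a larger maximal response.
compound 2, `O=C(O)CSc1ccc(NCc2cccc(Oc3ccccc3)c2)cc1`, reaches 84% in this assay.

Compound 2 is the lower of the two numbers, yet its nearest neighbour compound 1 sits so close that the two lie within the usual scatter of each other, so no real difference can be claimed. The next compound, compound 3, `CC(Cc1ccc(NCc2cccc(Oc3ccccc3)c2)cc1)C(=O)O`, changes only the acid-bearing arm on the shared core: 2-carboxypropyl in place of (carboxymethyl)sulfanyl on an aromatic carbon. For the measured compounds named here, the one step already seen that bears on this, a replacement of one acid arm by another, was a number 2 percentage points lower from compound 1 to compound 2 (within the scatter), which lay within the scatter. On that basis the new exchange is expected to leave the maximal response essentially unchanged, with an estimated step of a number 2 percentage points lower from compound 2 to compound 3 (within the scatter). Compound 3 is therefore estimated to reach 82% in this assay, with a likely range of 62% to 98%.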

Compound 3, largest response reached (reported as percent of maximum), in percent of the reference or control that the assay uses: 70%
For compound 3 the middle estimate is 12 percentage points above the measured one; low and high end bracket the measured number.
By their numbers in this assay, from the lowest: compound 3; then compounds 2 and 1 (each within the scatter of the next).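

At this place on the aromatic ring, the acid arm cannot be exchanged freely: in this assay, putting in 2-carboxypropyl gives a number 14 percentage points lower from compound 2 to compound 3 (beyond the scatter) and also a number 16 percentage points lower from compound 1 to compound 3 (beyond the scatter) when the arm it replaces is the plain carboxy group. For the compounds shown here, the earlier exchange, from carboxy to (carboxymethyl)sulfanyl, stayed within the scatter, so this is the first change here that clearly moves the maximal response, and it shows that keeping a carboxylic acid on the arm does not by itself hold the response. Nothing available explains why the 2-carboxypropyl arm gives less.

From the compounds shown here alone, it remains open whether an unbranched 2-carboxyethyl arm, lacking the methyl group of 2-carboxypropyl, would match compound 2 in the response. What a longer chain ending in a carboxylic acid would give is also unknown.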